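Swapping methyl for bromo on a well-tolerated amide

The source may report more compounds than this note shows. Statements on the series, on what has been measured and on what is new or still open speak of the compounds shown alone.

Compound 1 `Cc1cccc(C(=O)Nc2ncc(-c3ccccc3)n2C)c1` and compound 2 `Cc1ccc(C(=O)Nc2ncc(-c3ccccc3)n2C)cc1` share one core and differ only as 3-methylphenyl and 4-methylphenyl. In a toxicity assay on THP-1 cells (Homo sapiens) for inhibition (a higher number here means that more compound is tolerated, a lower number that less compound is tolerated), compound 1 gives > 50000 nM, which is a limit of the assay and not a number. In this assay compound 2 gives > 50000 nM, which is also a limit. Compound 2 therefore has no exact value to start from.

Compound 3 `Cn1c(-c2ccccc2)cnc1NC(=O)c1ccc(Br)cc1` differs from compound 2 by bromo in place of methyl on an aromatic carbon, or 4-methylphenyl to 4-bromophenyl. Among the measured compounds shown here, the only measured step is a step that the two limits leave unreadable from compound 1 to compound 2, and it involves a different change, so it offers no size to carry over. What remains is the limit of > 50000 nM in this assay, at which 2 of the 2 values shown sit. On that basis, no step beyond the scatter is expected in this assay, and compound 3 will probably also reach the limit and give no exact number. The expected change is a number no higher from compound 2 to compound 3 (the limit leaves the size open). For compound 3 the estimated value is 50000 nM, with an expected range from 20000 nM to 50000 nM.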

Compound 3, half-maximal cytotoxic concentration: > 100000 nM
Compound 3: no number, only a limit; the forecaster's own chance of this, stated with the estimate: 75%; middle value at least 2.0-fold (0.30 log units) from the limit.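

In this assay compound 3 gives > 100000 nM, which is again a limit of the assay and not a number. Among the compounds shown here, as compound 1, compound 2 and compound 3 all stand at limits, no step between them can be read. The compounds shown leave open at what concentration any of them would harm these cells, and whether bromo and methyl differ in this respect.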